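The source may report more compounds than this note shows. Statements on the series, on what has been measured and on what is new or still open speak of the compounds shown alone.

Values in a toxicity assay on HeLa cells (Homo sapiens) for cytotoxicity, read by MTT assay, with a stated time of 24 h; on this read-out higher numbers stand for weaker inhibition and lower numbers for stronger inhibition:
- Compound 1 `Cc1ncc([N+](=O)[O-])n1CC(O)CN1CCCC1`: > 5000000 nM
- Compound 2 `Cc1ncc([N+](=O)[O-])n1CC(O)CN1CCCCC1`: > 5000000 nM

Compound 2 stands at > 5000000 nM, which is a limit of the assay and not a number. Compound 3 `Cc1ncc([N+](=O)[O-])n1CC(O)Cn1cncn1` follows from compound 2 by one change: 1H-1,2,4-triazol-1-yl in place of piperidin-1-yl on a saturated chain carbon, two bonds along the chain from an oxygen on a saturated carbon. Going by the values given here, the only measured step bearing on this place is a step that the two limits leave unreadable from compound 1 to compound 2, so no size can be carried over. The sole reference point is the limit of > 5000000 nM in this assay, at which 2 of the 2 values shown sit. In this assay the expected step is a number no higher from compound 2 to compound 3 (the limit leaves the size open), with no direction readable. For compound 3 the estimate is 5000000 nM, with an expected range of 2000000 nM to 12000000 nM.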

Compound 3, half-maximal inhibitory concentration: 4970000 nM
Estimate against measurement, compound 3: 1.0-fold (0.00 log units) above; low and high end bracket the measured number.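

In this assay, going by these compounds alone, the 1H-1,2,4-triazol-1-yl group on this saturated chain carbon gives the first actual number, with compound 3 at 4970000 nM, and in place of piperidin-1-yl it gives a number no higher from compound 2 to compound 3 (the limit leaves the size open). In place of pyrrolidin-1-yl it gives a number no higher from compound 1 to compound 3 (the limit leaves the size open). The size of neither step can be read, so this change has no measurable size. The reference point for the series remains: the limit of > 5000000 nM in this assay, at which 2 of the 3 values shown sit.

Going by these compounds, whether any group at this place gives a value clearly removed from that limit stays open. A carboxylic acid or an open-chain dimethylamino group here would be the next comparison.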